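Lengthening methyl to butyl on compound 2

The source may report more compounds than this note shows. Statements on the series, on what has been measured and on what is new or still open speak of the compounds shown alone.

Compound 1 `CC(C)c1ccc(OC(C)(Cc2ccc(C(F)(F)F)cc2)C(=O)O)cc1`, compound 2 `Cc1ccc(CC(C)(Oc2ccc(C(C)C)cc2)C(=O)O)cc1` and compound 3 `CCc1cccc(CC(C)(Oc2ccc(C(C)C)cc2)C(=O)O)c1` were tested in a functional assay on the whole organism for inhibition, with Rattus norvegicus as the target; on this read-out higher numbers stand for an effect only at larger amounts of compound and lower numbers for an effect already at smaller amounts. Compound 2 gives < 1 mg/kg, which is a limit and not a number. Compound 1 gives < 5 mg/kg, also a limit. Compound 3 gives a true number, 0.5 mg/kg.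

Compound 4 `CCCCc1ccc(CC(C)(Oc2ccc(C(C)C)cc2)C(=O)O)cc1` differs from compound 2 by propyl in place of hydrogen on a saturated chain carbon bound to an aromatic carbon, turning methyl into butyl. The nearest measured changes are a step that the two limits leave unreadable from compound 1 to compound 2 and a step that the limit leaves unreadable from compound 2 to compound 3, so neither offers a size to carry over. Compound 3, at 0.5 mg/kg, shows that a group larger than methyl can still act at small doses. The expectation is therefore no step beyond the scatter in this assay: a step that the limit leaves unreadable from compound 2 to compound 4. Compound 4 is expected at 0.8 mg/kg, with an estimated range of 0.2 mg/kg to 3 mg/kg.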

Compound 4, dose for half-maximal effect: 1 mg/kg
Compound 4: middle estimate off by 1.3-fold (0.10 log units), on the low side, within the range that was stated.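

Butyl in place of methyl still leaves an effect at small doses: in this assay compound 4 gives a true number, 1 mg/kg, and the change reads as a number no lower from compound 2 to compound 4 (the limit leaves the size open). Compound 2 has a limit and not a number, so the size of that step cannot be read: the limit of < 1 mg/kg in this assay, at which 1 of the 4 values shown sits. Compound 1 also has only a limit, so its step to compound 4 cannot be read either: the limit of < 5 mg/kg in this assay, at which 1 of the 4 values shown sits.

Going by these compounds, whether a hexyl chain or an amine at this position would still act at such small doses stays open.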